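Ethyl to 4-methylpiperazin-1-yl on the aryl amide

The source may hold more compounds than are shown below. What is called first, only, known or untested is meant among the compounds shown, and "the series" means these compounds.

In a functional assay on MGC-803 cells (Homo sapiens) for inhibition, read by MTT assay, with a stated time of 72 h (a higher number here means a weaker inhibitor, a lower number a stronger inhibitor), compound 1 (`CCc1ccc(NC(=O)C2CCN(C/C=C/c3ccccc3)CC2)cc1`) gives 11600 nM. Compound 2 (`O=C(Nc1cccc(Br)c1)C1CCN(C/C=C/c2ccccc2)CC1`) gives 9110 nM, and compound 3 (`O=C(Nc1ccc(F)c(Br)c1)C1CCN(C/C=C/c2ccccc2)CC1`) gives 9270 nM. Compound 1 therefore stands level with both within the scatter: a 1.3-fold lower number from compound 1 to compound 2 (0.10 log units; within the scatter) and a 1.3-fold lower number from compound 1 to compound 3 (0.10 log units; within the scatter). The fluoro addition is equally small, a 1.0-fold higher number from compound 2 to compound 3 (0.01 log units; within the scatter).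

The next compound is compound 4 (`CN1CCN(c2ccc(NC(=O)C3CCN(C/C=C/c4ccccc4)CC3)cc2)CC1`), with 4-methylpiperazin-1-yl in place of ethyl on an aromatic carbon. The two aryl replacements starting from compound 1 bear most directly on this change, since they alter the same amide-nitrogen substituent. Neither of them introduces a group of this kind, so they are only a weak guide, and they give no direction. The expected step is none beyond the scatter, a 1.3-fold lower number from compound 1 to compound 4 (0.11 log units; within the scatter), although the uncertainty is wide. For compound 4 the estimated value is 9000 nM, with an expected range of 3000 nM to 25000 nM.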

Compound 4, half-maximal inhibitory concentration: 14000 nM
Compound 4: the middle estimate sits 1.6-fold (0.19 log units) below what was measured; the measured number falls inside the stated range.
By their numbers in this assay, from the lowest: compounds 2, 3, 1 and 4 (each within the scatter of the next).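

In this assay, the exchange of ethyl for 4-methylpiperazin-1-yl on this aromatic carbon, para to a large group, gives a 1.2-fold higher number from compound 1 to compound 4 (0.08 log units; within the scatter) and so leaves the reading in the same range as the smaller group. The earlier steps shown here covered only bromo and fluoro variants of the aryl group, whereas this one shows that a substituent carrying a six-membered non-aromatic ring with two nitrogens also produces no step beyond the scatter. No measurement is available that helps interpret this flat step.

All four compounds sit within the scatter of one another, so no change on the aryl amide has yet produced a clear effect. On these data alone, whether a carboxylic acid or a primary amine on this aromatic carbon would move the number beyond the scatter remains open.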